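Carbamate chain in place of phenoxymethyl on the quinone core

A few compounds are considered here, and "the series" means these few. Any claim that something is new, unique, unknown or untested is made for them only; others in the source may bear on it.

Compound 1, `CC1=C(N2CC2)C(=O)C(C(C)COC(N)=O)=C(N2CC2)C1=O`, 5.71 in a functional assay on L1210 cells (Mus musculus), with a stated time of 12 days; a higher number here means a more potent compound, by a factor of ten per unit of this negative logarithm, a lower number a less potent compound.
Compound 2, `CC1=C(N2CC2)C(=O)C(COc2ccccc2)=C(N2CC2)C1=O`, 4.71 in this assay.
Compound 3, `COCCOC(COC(N)=O)C1=C(N2CC2)C(=O)C(C)=C(N2CC2)C1=O`, 5.39 in this assay.

Compound 2 stands lowest of the three numbers in this assay: the nearest to it is compound 3 and the furthest is compound 1, and both gaps lie beyond the scatter. The unmeasured compound 4, `CC1=C(N2CC2)C(=O)C(CCCOC(N)=O)=C(N2CC2)C1=O`, differs from compound 2 in one place: 2-(carbamoyloxy)ethyl in place of phenoxy on a saturated chain carbon bound to a double-bonded ring carbon.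

Within the data shown here, only one measured step touches this region of the core, a number 0.32 log units lower from compound 1 to compound 3 (beyond the scatter), and it concerns the chain bearing the carbamate rather than the swap of phenoxy for a carbamate-bearing chain, so it bears only loosely. What the values show is that the two compounds carrying a carbamoyloxy group, compound 1 and compound 3, both sit well above compound 2 in this assay. On that basis compound 4 is expected to land near those two, a step of a number 0.79 log units higher from compound 2 to compound 4 (beyond the scatter) upward from compound 2. The estimate for compound 4 in this assay is 5.5, with a range from 5 to 6.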

Compound 4, logarithm of the reciprocal of the active concentration, log(1/C): 5.93
For compound 4 the middle estimate is 0.43 log units below the measured one; the range from low to high includes it.
By their numbers in this assay, from the lowest: compound 2; then compound 3; then compounds 1 and 4 (each within the scatter of the next).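

In this assay, putting 2-(carbamoyloxy)ethyl in place of phenoxy on a saturated chain carbon bound to a double-bonded ring carbon gives a number 1.22 log units higher from compound 2 to compound 4 (beyond the scatter) and is the only step shown that sets these two groups directly against each other. The carbamate-bearing chains of compound 1 and compound 4 have the same count of heavy atoms but are arranged differently, and the comparison gives a number 0.22 log units higher from compound 1 to compound 4 (within the scatter) so this assay does not separate these two arrangements. No measurement shown here accounts for the large gain on leaving phenoxy.

The step from compound 2 to compound 4 removes an aromatic ring and an ether oxygen and brings in a carbamate at the same time, so the compounds shown leave open how much of the gain belongs to the carbamoyloxy group and how much to the loss of phenoxy. A plain propyl chain, a chain ending in a hydroxyl group or an amine, or a longer chain ending in carbamoyloxy would each bear on that question and on how far the carbamate can sit from the shared core.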